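Half-life after swapping fluoro for methylsulfanyl

This account rests on a few compounds, and the source may have more. Where it says the series, first, only, none or still open, it means among the compounds named here.

Compound 1 `COc1ccc(-c2cc(C3=Nc4c(C(C)(C)C)nn(CCCO)c4C(=O)NC3)ccc2OC)c(OC)c1` gives 2 h in an ADME assay on microsomes from liver (Homo sapiens) for metabolic stability; on this read-out lower numbers stand for a shorter-lived compound and higher numbers for a longer-lived compound. Compound 2 `COc1ccc(C2=Nc3c(C(C)(C)C)nn(CCCO)c3C(=O)NC2)cc1-c1ccccc1F` gives 0.8 h in this assay, the lowest of the two numbers; the step of a 2.5-fold lower number from compound 1 to compound 2 (0.40 log units; beyond the scatter) is the only one measured so far. Compound 3 `COc1ccc(C2=Nc3c(C(C)(C)C)nn(CCCO)c3C(=O)NC2)cc1-c1ccccc1SC` is not yet measured. It differs from compound 2 by methylsulfanyl in place of fluoro on an aromatic carbon. Among the measured compounds shown here, no measured step exchanges fluoro for methylsulfanyl, so a 2.5-fold lower number from compound 1 to compound 2 (0.40 log units; beyond the scatter) bears on it only by showing that altering the group in question can move the number. No step beyond the scatter is expected; the estimate for compound 3 is 0.6 h (range 0.25 h to 1.5 h), an expected step of a 1.3-fold lower number from compound 2 to compound 3 (0.12 log units; within the scatter).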

Compound 3, half-life: 0.85 h
Estimate against measurement, compound 3: 1.4-fold (0.15 log units) below; the measured number falls inside the stated range.
By their numbers in this assay, from the lowest: compounds 2 and 3 (each within the scatter of the next); then compound 1.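

In this assay, methylsulfanyl in place of fluoro on the aromatic carbon gives a 1.1-fold higher number from compound 2 to compound 3 (0.03 log units; within the scatter) and so does not separate the two groups at this position. Replacing 2,4-dimethoxyphenyl with 2-(methylsulfanyl)phenyl gives a 2.4-fold lower number from compound 1 to compound 3 (0.37 log units; beyond the scatter) and so shows that the gap to compound 1 is not confined to the 2-fluorophenyl compound. Going by these compounds, whether an amine or a carboxylic acid at this ortho place would keep the number of compound 2 or move it remains open. Nothing at hand accounts for these numbers.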